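Sulfonyl swap in a series sitting at its limit

The source may hold more compounds than are shown below. What is called first, only, known or untested is meant among the compounds shown, and "the series" means these compounds.

Measured in an ADME assay on HEK293 cells (Homo sapiens) for cytotoxicity, read by resazurin assay, with a stated time of 48 h (a lower number here means that less compound is tolerated, a higher number that more compound is tolerated), with each value a limit of the assay:
compound 1 `O=S(=O)(Nc1ccc(-c2nc3ccccc3o2)cc1)c1ccccc1Cl` gives > 100000 nM
compound 2 `CS(=O)(=O)Nc1ccc(-c2nc3ccccc3o2)cc1` gives > 100000 nM
compound 3 `COc1cccc(S(=O)(=O)Nc2ccc(-c3nc4ccccc4o3)cc2)c1` gives > 100000 nM

Within the data shown here, compound 3 stands with its companions, with the limit of > 100000 nM in this assay, at which 3 of the 3 values shown sit, as the only reading and no number for it. Among the measured compounds shown here, the move to compound 4 `O=S(=O)(Nc1ccc(-c2nc3ccccc3o2)cc1)c1ccc(Cl)cc1` puts 4-chlorophenyl in place of 3-methoxyphenyl on a sulfonyl sulfur as the single change. For the measured compounds named here, three measured steps bear on it: a step that the two limits leave unreadable from compound 1 to compound 3 and a step that the two limits leave unreadable from compound 2 to compound 3 and a step that the two limits leave unreadable from compound 1 to compound 2 and none of them has a readable size. Swapping the group on the sulfonyl sulfur has so far never brought a value off the limit. The expected move is a step that the limit leaves unreadable from compound 3 to compound 4 and no step beyond the scatter is foreseen in this assay for it. The estimate for compound 4 is 150000 nM with an expected range from 80000 nM to 300000 nM in this measurement.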

Compound 4, half-maximal cytotoxic concentration: > 100000 nM
Compound 4: a limit, no number; the forecaster's own chance of this, stated with the estimate: 85%; the middle value does not contradict the limit.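

Compound 4 gives > 100000 nM, a limit and not a number, so its steps from compound 1, compound 2 and compound 3 cannot be read. Left open is whether any group on the sulfonyl sulfur brings a value off the limit.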